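Swapping the Amide Aryl Group: From Compound 3 to Compound 4

This account rests on a few compounds, and the source may have more. Where it says the series, first, only, none or still open, it means among the compounds named here.

Three amides share one core. Compound 1 `Cc1ccc(NC(=O)COc2ccc3cc(/C=C4/SC(=O)NC4=O)ccc3c2)cc1` gives 1700 nM in an assay on isolated protein for inhibition of histone deacetylase 4 (Homo sapiens), with a stated time of 1 h (a higher number here means a weaker inhibitor, a lower number a stronger inhibitor), compound 2 `O=C(COc1ccc2cc(/C=C3/SC(=O)NC3=O)ccc2c1)Nc1ccccc1` gives 2100 nM, and compound 3 `O=C(COc1ccc2cc(/C=C3/SC(=O)NC3=O)ccc2c1)Nc1ccc(Cl)c(Cl)c1` gives 5500 nM. Compound 3 thus stands at the highest number of the three, with compound 2 nearest and compound 1 furthest, both beyond the scatter. The step of a 1.2-fold higher number from compound 1 to compound 2 (0.09 log units; within the scatter) lies within the scatter, whereas a 3.2-fold higher number from compound 1 to compound 3 (0.51 log units; beyond the scatter) and a 2.6-fold higher number from compound 2 to compound 3 (0.42 log units; beyond the scatter) are modest. Compound 4 `Cc1cc(NC(=O)COc2ccc3cc(/C=C4/SC(=O)NC4=O)ccc3c2)no1` carries 5-methyl-1,2-oxazol-3-yl in place of 3,4-dichlorophenyl on an amide-type nitrogen. Among the compounds with values here, the only steps that bear on it are those two aryl exchanges on the amide nitrogen, each modest, and neither covers a heteroaryl. A modest step toward lower numbers is therefore expected, a 1.8-fold lower number from compound 3 to compound 4 (0.26 log units; within the scatter), with wide uncertainty. Compound 4 is estimated at 3000 nM in this assay, within 1200 nM to 8000 nM.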

Compound 4, half-maximal inhibitory concentration: 1700 nM
The estimate for compound 4 lay 1.8-fold (0.25 log units) above the measured number; the measured number falls inside the stated range.
By their numbers in this assay, from the lowest: compounds 1, 4 and 2 (each within the scatter of the next); then compound 3.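

In this assay, placing a five-membered aromatic ring with 2 hetero atoms on the amide-type nitrogen gives a 3.2-fold lower number from compound 3 to compound 4 (0.51 log units; beyond the scatter), while the same group gives a 1.2-fold lower number from compound 2 to compound 4 (0.09 log units; within the scatter) and no change at the digits printed from compound 1 to compound 4 (within the scatter). The position therefore accepts this ring as readily as phenyl or 4-methylphenyl, and among these four amides only the 3,4-dichlorophenyl of compound 3 stands apart. Nothing available explains this result.

Going by these compounds, it remains open whether an amine, a carboxylic acid or a longer chain in place of the 5-methyl-1,2-oxazol-3-yl group on the amide-type nitrogen would keep the number in this range.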